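Swapping a Sulfonyl Group for Pyridin-3-yl

The source may hold more compounds than are shown below. What is called first, only, known or untested is meant among the compounds shown, and "the series" means these compounds.

Measured in a functional assay for inhibition, with Homo sapiens as the target; a lower number here means a stronger inhibitor, a higher number a weaker inhibitor:
- compound 1 `CCOCCS(=O)(=O)N[C@@H](CNC(=O)c1ccc2c(c1)C(=O)N(CCC1CCNCC1)C2)C(=O)O`: 8 nM
- compound 2 `CCCCNS(=O)(=O)N[C@@H](CNC(=O)c1ccc2c(c1)C(=O)N(CCC1CCNCC1)C2)C(=O)O`: 19 nM
- compound 3 `O=C(NC[C@H](NS(=O)(=O)c1cccs1)C(=O)O)c1ccc2c(c1)C(=O)N(CCC1CCNCC1)C2`: 7 nM

Compound 1 sits level with its nearest neighbour, at a 1.1-fold lower number from compound 1 to compound 3 (0.06 log units; within the scatter). Its furthest neighbour gives a clearer gap, at a 2.4-fold higher number from compound 1 to compound 2 (0.38 log units; beyond the scatter).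

The unmeasured compound 4 `O=C(NC[C@H](NS(=O)(=O)c1cccnc1)C(=O)O)c1ccc2c(c1)C(=O)N(CCC1CCNCC1)C2` differs from compound 1 in one place: pyridin-3-yl in place of 2-ethoxyethyl on a sulfonyl sulfur. In short, pyridin-3-yl stands in place of 2-ethoxyethyl on a sulfonyl sulfur.

The closest guide is compound 3, which also carries a ring group on the sulfonyl sulfur, with a 1.1-fold lower number from compound 1 to compound 3 (0.06 log units; within the scatter). The butylamino group of compound 2 is less like the incoming group, and its steps are modest: a 2.4-fold higher number from compound 1 to compound 2 (0.38 log units; beyond the scatter) and a 2.7-fold lower number from compound 2 to compound 3 (0.43 log units; beyond the scatter). Three compounds are a thin basis, and none of them carries pyridin-3-yl. Even so, no step beyond the scatter is expected in this assay.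

The estimated step is a 1.1-fold higher number from compound 1 to compound 4 (0.05 log units; within the scatter). Compound 4 is expected at about 9 nM, within an estimated range of 4 nM to 22 nM.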

Compound 4, half-maximal inhibitory concentration: 15 nM
The estimate for compound 4 lay 1.7-fold (0.22 log units) below the measured number; low and high end bracket the measured number.
By their numbers in this assay, from the lowest: compounds 3, 1, 4 and 2 (each within the scatter of the next, the first and the last beyond it).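

In this assay a six-membered aromatic ring with a ring nitrogen is accepted on the sulfonyl sulfur, since pyridin-3-yl lies within the scatter of 2-ethoxyethyl, with a 1.9-fold higher number from compound 1 to compound 4 (0.27 log units; within the scatter) as the step, and of butylamino, with a 1.3-fold lower number from compound 2 to compound 4 (0.10 log units; within the scatter) as the step. What is new is that two aromatic rings at this place need not read alike: replacing thiophen-2-yl with pyridin-3-yl gives a 2.1-fold higher number from compound 3 to compound 4 (0.33 log units; beyond the scatter) as a modest step, so carrying a ring on this sulfur does not by itself fix the number. Nothing measured here accounts for that gap.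

The compounds shown leave open whether a plain phenyl ring would read closer to thiophen-2-yl or to pyridin-3-yl. They also leave open how pyridin-4-yl, or an amine or a carboxylic acid added to the ring, would move the number.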